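A few compounds are considered here, and "the series" means these few. Any claim that something is new, unique, unknown or untested is made for them only; others in the source may bear on it.

Three compounds have been measured in a physicochemical assay for lipophilicity, at pH 7.4; a lower number here means a more polar compound, a higher number a more lipophilic compound:

compound 1, `CC(=O)N1CCc2cc(-c3cccc4c3CCCC4)cc(N3CCCC3=O)c21`, with 3.5;
compound 2, `CC(=O)N1CCc2cc(-c3cccc4c3CCCC4)cc(N3CCCCC3=O)c21`, with 3.8;
compound 3, `O=C1CCCN1c1cnc(NCc2c(F)ccc3c2CCO3)n2cnnc12`, with 1.3.

Compound 1 and compound 2 share one core and differ in a single place: 2-oxopiperidin-1-yl in place of 2-oxopyrrolidin-1-yl on an aromatic carbon. In this assay that change gave a number 0.30 log units higher from compound 1 to compound 2 (within the scatter). Compound 3 is built on a different core, and how the core of compound 3 differs from the core of compound 1 is not broken down here. In this assay compound 3 gives the lowest of the three numbers, and its distance to compound 1 and to compound 2 lies beyond the scatter in each case.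

Compound 4, `O=C1CCCCN1c1cnc(NCc2c(F)ccc3c2CCO3)n2cnnc12`, has not yet been measured. It stands to compound 3 as compound 2 stands to compound 1: 2-oxopiperidin-1-yl in place of 2-oxopyrrolidin-1-yl on an aromatic carbon. The surroundings are not identical. In compound 1 the group sits on a six-membered aromatic ring of carbon only, meta to a large group, whereas in compound 3 it sits on a six-membered aromatic ring with two nitrogen, two atoms from the ring nitrogen and para to a large group, so this is the same kind of change rather than the same change. The step is nonetheless expected to be of a similar size, a number 0.30 log units higher from compound 3 to compound 4 (within the scatter), because the earlier step was a number 0.30 log units higher from compound 1 to compound 2 (within the scatter). For compound 4 the expected value in this assay is 1.6, with a range from 1.2 to 2.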

Compound 4, distribution coefficient: 1.3
Beside the measured number, compound 4's estimate is 0.30 log units above it, and the stated range covers the measured number.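

Placing 2-oxopiperidin-1-yl in place of 2-oxopyrrolidin-1-yl on an aromatic carbon gave, in this assay, no change at the digits printed from compound 3 to compound 4 (within the scatter) on one core and a number 0.30 log units higher from compound 1 to compound 2 (within the scatter) on the other. On both cores, then, this change left the read-out within the usual scatter of repeated measurements, and the two pairs agree on that point even though the group sits in different surroundings on each core. This does not show that the step has a fixed size on every core or that the two cores respond differently to it, since two pairs within the scatter cannot separate those readings, and nothing available bears on why the step reads as it does.

The compounds shown leave open how this assay would respond on the core of compound 3 to a group of another kind on the same aromatic carbon, such as an amine, a carboxylic acid or a longer chain ending in an open amide. They also leave open whether a larger lactam, 2-oxoazepan-1-yl, would stay within the scatter of compound 3 and compound 4, and whether the same change would do so on a third core.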